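Nitro for methoxy at the limit of growth inhibition

A few compounds are considered here, and "the series" means these few. Any claim that something is new, unique, unknown or untested is made for them only; others in the source may bear on it.

Compound 1 (`CC(C)(C)NCc1c(C(=O)O)nn(-c2ccccc2)c1-c1ccc(Cl)cc1`) has the limit > 652000 nM in an ADME assay on HaCaT cells (Homo sapiens) for inhibition, read by sulforhodamine B assay, with a stated time of 48 h; on this read-out lower numbers stand for stronger inhibition of growth and higher numbers for weaker inhibition of growth
Compound 2 (`COc1ccc(-c2c(CNC(C)(C)C)c(C(=O)O)nn2-c2ccccc2)cc1`) has the limit > 659000 nM in this assay

Within the data shown here, neither compound has yielded a number so far. Compound 2 stands at > 659000 nM in this assay, and this is a limit. Compound 3 (`CC(C)(C)NCc1c(C(=O)O)nn(-c2ccccc2)c1-c1ccc([N+](=O)[O-])cc1`), not yet measured, has nitro in place of methoxy on an aromatic carbon, para to a large group (nitro in place of methoxy on an aromatic carbon). Among the measured compounds shown here, one measured step bears on this change, at the same place: a step that the two limits leave unreadable from compound 1 to compound 2. It gives no size to carry over, so no step beyond the usual scatter is expected in this assay, and no direction can be argued. Compound 3 is expected to be reported as a limit as well. The estimated change is an at least 1.0-fold lower number from compound 2 to compound 3 (0.01 log units; that floor lies within the scatter). For compound 3 the estimate is 640000 nM, with an expected range from 250000 nM to 1000000 nM.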

Compound 3, concentration for 50% growth inhibition: > 634000 nM
Compound 3: no number, only a limit; the forecaster's own chance of this, stated with the estimate: 85%; the middle value lies beyond the limit too.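

Among these compounds, compound 1, compound 2 and compound 3 are each reported only as a limit in this assay, and no step among them can be read. The compounds shown leave open whether chloro, methoxy and nitro at this place differ at all in this assay.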